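This account rests on a few compounds, and the source may have more. Where it says the series, first, only, none or still open, it means among the compounds named here.

Working notes on the series. Within the data shown here, compound 1 `COc1cccc(S(=O)(=O)c2ccc(NC(=O)C(C)(O)C(F)(F)F)cc2)c1` is the only compound so far with a number in a functional assay (Cavia porcellus) with sulfonylurea receptors; K-ATP channels (Homo sapiens) as the target; on this read-out lower numbers stand for stronger inhibition and higher numbers for weaker inhibition: compound 1 gives 16000 nM. Compound 2 `CC(O)(C(=O)Nc1ccc(S(=O)(=O)c2cccc(C(F)(F)F)c2)cc1)C(F)(F)F` is the other measured compound. In this assay compound 2 is reported only as a limit of the assay, > 30000 nM. Among the measured compounds shown here, the one measured step, an at least 1.8-fold higher number from compound 1 to compound 2 (0.27 log units; that floor lies within the scatter), thus rests on the limit of > 30000 nM in this assay, at which 1 of the 2 values shown sits, and not on a second number, so its true size is unknown beyond its floor.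

Compound 3 `CN(c1ccccc1)S(=O)(=O)c1ccc(NC(=O)C(C)(O)C(F)(F)F)cc1` is not yet measured. Against compound 1 the change is methyl(phenyl)amino in place of 3-methoxyphenyl on a sulfonyl sulfur. This exchanges one whole substituent on the sulfonyl sulfur for another, whereas the measured step only exchanged a substituent on an aromatic carbon within the same ring. For the measured compounds named here, that step shows only that a change on this side of the core gave a weaker number, with its size bounded by the limit; no step of the present kind is available. For this assay a step within the scatter, or toward weaker inhibition, is expected, a 1.3-fold higher number from compound 1 to compound 3 (0.10 log units; within the scatter). Compound 3 is therefore estimated at 20000 nM, with a range from 6000 nM to 60000 nM, and a fair chance that only a limit is reported.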

Compound 3, half-maximal inhibitory concentration: 2000 nM
The estimate for compound 3 lay 10-fold (1.00 log units) above the measured number; the measured number lies below the stated range.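

In this assay, the exchange on the sulfonyl sulfur gives an 8.0-fold lower number from compound 1 to compound 3 (0.90 log units; beyond the scatter), the only step shown that is read between two numbers and lies beyond the scatter. This makes the substituent on the sulfonyl sulfur a place where the read-out moves toward stronger inhibition. The two groups have the same heavy-atom count and each holds one six-membered aromatic ring of carbon only, so the step does not come with a change in either count; what differs is that methyl(phenyl)amino attaches through nitrogen and has no hydrogen-bond acceptor by the count, whereas 3-methoxyphenyl has one. Compound 2 adds no second number for comparison, and the step to it remains a floor: the limit of > 30000 nM in this assay, at which 1 of the 3 values shown sits.

The compounds shown leave open whether the stronger inhibition belongs to the nitrogen attachment, to the methyl on that nitrogen, or to the loss of the methoxy group. A hydrogen or an ethyl in place of that methyl, or a saturated amine such as piperidine on the sulfonyl sulfur, would begin to separate these readings.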